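This account rests on a few compounds, and the source may have more. Where it says the series, first, only, none or still open, it means among the compounds named here.

In a functional assay on CHO cells for positive allosteric modulation of metabotropic glutamate receptor 2 (Homo sapiens), read by GTPgammaS binding, with a stated time of 30 min (on this read-out lower numbers stand for smaller maximal responses and higher numbers for larger maximal responses), compound 1 `N#Cc1c(N2CCC(c3ccccc3)CC2)ccn2c(CC3CC3)nnc12` gives 278%, the highest of the three measured numbers. Compound 3 `N#Cc1c(N2CCC(c3ccccc3)CC2)ccn2c(CN3CCCC3)nnc12` gives 240% and compound 2 `COCc1nnc2c(C#N)c(N3CCC(c4ccccc4)CC3)ccn12` gives 196%. The measured steps were a number 38 percentage points lower from compound 1 to compound 3 (beyond the scatter), a number 82 percentage points lower from compound 1 to compound 2 (beyond the scatter) and a number 44 percentage points higher from compound 2 to compound 3 (beyond the scatter). Compound 4 `Clc1c(N2CCC(c3ccccc3)CC2)ccn2c(CC3CC3)nnc12` differs from compound 1 in another place: chloro in place of cyano on an aromatic carbon None of the three measured steps touches this position, since each of them varied the group on the saturated chain carbon, so they offer no direct guide to the size or direction of this change. Only a modest drop, possibly within the scatter, is expected, a number 48 percentage points lower from compound 1 to compound 4 (beyond the scatter). Compound 4 is therefore estimated at 230%, expected to fall between 140% and 320%.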

Compound 4, largest response reached (Emax), in percent of the reference or control that the assay uses: 343%
Estimate against measurement, compound 4: 113 percentage points below; the whole stated range lies below it.
By their numbers in this assay, from the lowest: compound 2; then compound 3; then compound 1; then compound 4.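

In this assay, chloro in place of cyano on this aromatic carbon gives a number 65 percentage points higher from compound 1 to compound 4 (beyond the scatter), so the response depends strongly on this position as well as on the saturated chain carbon. The hydrogen-bond acceptor of the cyano group is not needed for a large response in this pair, since chloro has none. The data shown offer no measured explanation for the rise. On these data alone, it remains open how bromo, fluoro or methyl would behave on this carbon, and whether chloro would also raise the response with the methoxy of compound 2 or the pyrrolidin-1-yl of compound 3 on the chain carbon.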